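Nitro for trifluoromethyl: working notes on four compounds

The compounds below may be only part of what the source reports. "The series", "measured", "known", "first", "only" and "open" are said of these compounds alone.

Measured so far:
- compound 1, `FC(F)(F)c1ccc(COc2ccc(Nc3ncnc4cc5c(cc34)OCCOCCOCCOCCO5)cc2)cc1`: in a functional assay on A549 cells (Homo sapiens) for antiproliferative activity, read by MTT assay, with a stated time of 72 h (on this read-out higher numbers stand for weaker inhibition and lower numbers for stronger inhibition), compound 1 gives 8560 nM.
- compound 2, `FC(F)(F)c1ccc(COc2cccc(Nc3ncnc4cc5c(cc34)OCCOCCO5)c2)cc1`: in this assay compound 2 gives only the limit > 100000 nM, not a number.
- compound 3, `O=[N+]([O-])c1ccc(COc2ccc(Nc3ncnc4cc5c(cc34)OCCOCCOCCOCCO5)cc2)cc1`: in this assay compound 3 gives only the limit > 100000 nM, not a number.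

Compound 1 and compound 3 differ in one place, (nitro in place of trifluoromethyl on an aromatic carbon). In this assay this change gives an at least 11-fold higher number from compound 1 to compound 3 (1.06 log units; beyond the scatter), so the nitro compound falls off the measurable range. The difference between the core of compound 1 and the core of compound 2 is not broken down here; the two values show that compound 2 sits at the limit while compound 1 does not.

Compound 4, `O=[N+]([O-])c1ccc(COc2cccc(Nc3ncnc4cc5c(cc34)OCCOCCO5)c2)cc1`, has not yet been measured. It stands to compound 2 as compound 3 stands to compound 1: nitro in place of trifluoromethyl on an aromatic carbon, the same change in the same place, since both "place" descriptions read alike.

For compound 4 in this assay a step that the limit leaves unreadable from compound 2 to compound 4 is expected from compound 2, meaning another value that is only a limit. Among the measured compounds shown here, this expectation rests on (the limit of > 100000 nM in this assay, at which 2 of the 3 values shown sit), where compound 2 already sits, and on the measured step from compound 1 to compound 3, an at least 11-fold higher number from compound 1 to compound 3 (1.06 log units; beyond the scatter), which moved the only numerical value in the set out to that limit. Compound 4 is therefore estimated at 300000 nM, most likely returned as a limit rather than a number, with a range of 100000 nM to 1000000 nM.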

Compound 4, half-maximal inhibitory concentration: 15500 nM
Compound 4: middle estimate off by 19-fold (1.29 log units), on the high side; measured number outside the range, below it.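

In this assay the nitro for trifluoromethyl change gives an at least 6.4-fold lower number from compound 2 to compound 4 (0.80 log units; beyond the scatter), so the direction of the change does not carry from one core to the other in this pair of cores: the same change on two cores in this assay, an at least 11-fold higher number (1.06 log units; beyond the scatter) from compound 1 to compound 3 and an at least 6.4-fold lower number (0.80 log units; beyond the scatter) from compound 2 to compound 4, at least 75-fold (1.87 log units) apart, beyond the scatter of two such steps

Each of the two steps has one end at a limit of the assay, so only its direction and minimum size can be read, not its true size: the limit of > 100000 nM in this assay, at which 2 of the 4 values shown sit.

The core of compound 1 and the core of compound 2 differ in more than one place, so these four compounds do not show which of those differences goes with the reversal, or why it occurs, and two cores give no rule for a third.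

Open, as far as these compounds go, is whether a core carrying only one of those differences follows the core of compound 1 or the core of compound 2 under the same change. Also open, from the compounds shown here alone, is how a nitrile or an amine, set in the same place on the aromatic ring on each core, would compare with trifluoromethyl and nitro, and whether the reversal would appear with those groups as well.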